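The source may report more compounds than this note shows. Statements on the series, on what has been measured and on what is new or still open speak of the compounds shown alone.

The account starts from compound 1 `COC(=O)c1cccc(Oc2ccc(N(C)C)cc2)c1` and compound 2 `CCOC(=O)c1ccc(Oc2ccc(N(C)C)cc2)cc1`, both tested in a functional assay on HL-60 cells (Homo sapiens) for antiproliferative activity; a lower number here means a stronger inhibitor, a higher number a weaker inhibitor. Compound 1 gives > 20000 nM, which is a limit of the assay and not a number. Compound 2 gives > 20000 nM, also a limit, so it has no measured potency. Both compounds stand at the limit of > 20000 nM in this assay, at which 2 of the 2 values shown sit. Compound 3 `CCOC(=O)c1ccc(Oc2ccc(Cl)cc2)cc1` keeps the rest of compound 2 and makes a single change, chloro in place of dimethylamino on an aromatic carbon, para to a large group. Among the measured compounds shown here, no step between measured compounds is available as a guide, so the expectation in this assay is for no step beyond the scatter, with a report of only a limit the likeliest outcome. The estimated change is a step that the limit leaves unreadable from compound 2 to compound 3. Compound 3 is expected to come in at about 25000 nM, within an estimated range of 10000 nM to 60000 nM.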

Compound 3, half-maximal inhibitory concentration: > 20000 nM
Compound 3 ended at the assay's limit (the forecaster's own chance of this, stated with the estimate: 75%); the middle value does not contradict the limit.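

In this assay compound 3 gives > 20000 nM, a limit of the assay and not a number. Compound 2 also sits at a limit, so no step between compound 2 and compound 3 can be read: the limit of > 20000 nM in this assay, at which 3 of the 3 values shown sit.

The compounds shown leave open whether chloro and dimethylamino differ at all in this assay.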